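The compounds below may be only part of what the source reports. "The series", "measured", "known", "first", "only" and "open" are said of these compounds alone.

Compound 3 `Cc1ccc(C(=O)Nc2cccc(NC(=O)COc3ccc4c(=O)ccoc4c3)c2)cc1` — 183 nM
Compound 1 `COc1ccc(OCC(=O)Nc2cccc(NC(=O)c3ccc(N(C)C)cc3)c2)cc1F` — 1820 nM
Compound 2 `Cc1c(OCC(=O)Nc2cccc(NC(=O)c3ccc(N(C)C)cc3)c2)ccc2c(=O)ccoc12` — > 10000 nM

In an assay on isolated protein for inhibition of Rho-associated protein kinase 1 (Homo sapiens), read by scintillation counting, radiometric assay and 33P incorporation, with a stated time of 40 min, in the presence of a further agent that is not named here (a higher number here means a weaker inhibitor, a lower number a stronger inhibitor), compound 3 gives 183 nM, the lowest of the two numbers shown, while compound 1 gives 1820 nM, a gap beyond the scatter. Compound 2 reaches only a limit, > 10000 nM (the limit of > 10000 nM in this assay, at which 1 of the 3 values shown sits), and so contributes no number. Compound 4 `NCc1ccc(C(=O)Nc2cccc(NC(=O)COc3ccc4c(=O)ccoc4c3)c2)cc1` has not yet been measured. It differs from compound 3 in one place: amino in place of hydrogen on a saturated chain carbon bound to an aromatic carbon, that is, methyl to aminomethyl, 4-methylphenyl to 4-(aminomethyl)phenyl. No measured pair shown here carries this change, so no step of the same kind can be leaned on. The step of a 2.0-fold lower number from compound 3 to compound 4 (0.31 log units; beyond the scatter) is expected to be modest and toward a lower number. The estimate for compound 4 is 90 nM, between 25 nM and 400 nM.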

Compound 4, half-maximal inhibitory concentration: 532 nM
The estimate for compound 4 lay 5.9-fold (0.77 log units) below the measured number; measured number above the stated range.
By their numbers in this assay, from the lowest: compound 3; then compound 4; then compound 1. At a limit, above all of these: compound 2.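

In this assay the change from 4-methylphenyl to 4-(aminomethyl)phenyl gives a 2.9-fold higher number from compound 3 to compound 4 (0.46 log units; beyond the scatter). This is the first step shown at this position, and it shows that the added amino group on the saturated chain carbon bound to an aromatic carbon is tolerated but brings no gain, with the methyl group remaining the better of the two. Nothing measured here gives a reason for this step. From the compounds shown here alone, whether a hydroxymethyl group, a carboxylic acid or a longer aminoethyl chain in this place would stand nearer compound 3 or compound 4 stays open.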